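Methyl to Hydrogen on an Amide-Type Nitrogen

The compounds below may be only part of what the source reports. "The series", "measured", "known", "first", "only" and "open" are said of these compounds alone.

Measured so far:
compound 1, `C/C(=N\NC(=S)N1CCCCC1)c1ccc([N+](=O)[O-])cc1`: "not determined" (no result reported)
compound 2, `C/C(=N\NC(=S)N(C)C)c1ccc([N+](=O)[O-])cc1`: > 400 uM

Both compounds were set up for an ADME assay on THP-1 cells (Homo sapiens) for cytotoxicity, with a stated time of 48 h; a lower number here means a stronger inhibitor, a higher number a weaker inhibitor. For compound 1 no result was reported in this assay. Compound 2 gave only a limit of the assay in this assay, > 400 uM, which is not a number in the ordinary sense; of the two entries shown, it is the one that sits at the limit, as the limit of > 400 uM in this assay, at which 1 of the 2 values shown sits, records. Among the compounds with values here, compound 2 therefore stands at the weak end of what this assay can report, and no measured step between two compounds exists here to calibrate a change.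

The next compound is compound 3, `CNC(=S)N/N=C(\C)c1ccc([N+](=O)[O-])cc1`. It differs from compound 2 by hydrogen in place of methyl on an amide-type nitrogen. With only a limit to start from, the step in this assay is expected to be none beyond the usual scatter, and compound 3 is estimated to give 450 uM, within 150 uM to 1000 uM, a step that is expected to be a step that the limit leaves unreadable from compound 2 to compound 3.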

Compound 3, concentration for 50% inhibition: > 400 uM
Compound 3: a limit, no number; the forecaster's own chance of this, stated with the estimate: 75%; the middle value lies beyond the limit too.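

In this assay, within the data shown here, compound 2 and compound 3 both give only a limit, not a number, so no step between them can be read: the limit of > 400 uM in this assay, at which 2 of the 3 values shown sit.

Going by these compounds, whether in this assay hydrogen in place of methyl on an amide-type nitrogen changes the result at all stays open, as does how compound 1 compares with compound 2 and compound 3.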